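The source may hold more compounds than are shown below. What is called first, only, known or untested is meant among the compounds shown, and "the series" means these compounds.

Compound 1 `O=C1COc2ccc(-c3[nH]c(-c4ccc(C(F)(F)F)cc4)nc3-c3ccccc3)cc2N1`: 0.6% in a functional assay on MV4-11 cells (Homo sapiens) for cytotoxicity, read by colorimetric assay and MTT assay, with a stated time of 3 days, tested at 20 uM; on this read-out higher numbers stand for a weaker effect at the one concentration tested and lower numbers for a stronger effect.
Compound 2 `O=C1COc2ccc(-c3[nH]c(-c4ccc(F)cc4)nc3-c3ccccc3)cc2N1`: 1.1%.
Compound 3 `O=C1COc2ccc(-c3nn(-c4ccc(F)cc4)cc3-c3ccccc3)cc2N1`: 92.6%.

Compound 3 stands highest of the three numbers, separated from compound 2 and compound 1 by gaps beyond the scatter. Compound 4 `COc1ccc(-n2cc(-c3ccccc3)c(-c3ccc4c(c3)NC(=O)CO4)n2)cc1` differs from compound 3 by methoxy in place of fluoro on an aromatic carbon. Within the data shown here, the only measured step, a number 0.5 percentage points higher from compound 1 to compound 2 (within the scatter), also exchanges one group for another on a phenyl ring, but on the core shared by compound 1 and compound 2, not on the core of compound 3; it stayed within the scatter. Among the measured compounds shown here, no step on the core of compound 3 has been measured. Compound 4 is therefore expected to move little, a number 4.6 percentage points lower from compound 3 to compound 4 (within the scatter). Compound 4 is estimated at 88%, in a range from 68% to 100%.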

Compound 4, a percentage reported as activity, at one concentration (the size of the read-out at that concentration, not a potency): 59.9%
The estimate for compound 4 lay 28.1 percentage points above the measured number; the measured number lies below the stated range.
By their numbers in this assay, from the lowest: compounds 1 and 2 (each within the scatter of the next); then compound 4; then compound 3.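

In this assay, the exchange of 4-fluorophenyl for 4-methoxyphenyl on the core of compound 3 gave a number 32.7 percentage points lower from compound 3 to compound 4 (beyond the scatter) and thus a stronger effect at the one concentration tested. This shows that the group on this ring can matter on this core, which the exchange on the core shared by compound 1 and compound 2 did not show.

As far as these compounds go, how an amine, a hydroxyl or a longer ether chain such as ethoxy would read at this place remains open. No evidence at hand accounts for the step.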